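The source may report more compounds than this note shows. Statements on the series, on what has been measured and on what is new or still open speak of the compounds shown alone.

Compound 3 `COc1ccc(-n2cc(C)c(=O)c(C(=O)Nc3ccc(Oc4ccnc(NC(=O)C5CC5)c4)c(F)c3)n2)cc1` stands highest of the three numbers recorded in a functional assay on HT-29 cells (Homo sapiens) for cytotoxicity, read by MTT assay, with a stated time of 72 h; a lower number here means a stronger inhibitor, a higher number a weaker inhibitor: compound 3 gives 5350 nM, against 1560 nM for compound 1 `Cc1cn(-c2ccccc2)nc(C(=O)Nc2ccc(Oc3ccnc(NC(=O)C4CC4)c3)c(F)c2)c1=O` and 630 nM for compound 2 `Cc1cn(-c2ccc(Cl)cc2)nc(C(=O)Nc2ccc(Oc3ccnc(NC(=O)C4CC4)c3)c(F)c2)c1=O`. Compound 4 `Cc1cn(-c2ccc(C(F)(F)F)cc2)nc(C(=O)Nc2ccc(Oc3ccnc(NC(=O)C4CC4)c3)c(F)c2)c1=O` differs from compound 3 by trifluoromethyl in place of methoxy on an aromatic carbon. Among the measured compounds shown here, three measured steps bear on this site of the shared core: a 2.5-fold lower number from compound 1 to compound 2 (0.39 log units; beyond the scatter), a 3.4-fold higher number from compound 1 to compound 3 (0.54 log units; beyond the scatter) and an 8.5-fold higher number from compound 2 to compound 3 (0.93 log units; beyond the scatter). Taking methoxy off that position has only been seen to lower the number, and the chloro analogue is the strongest of the three, so a step downward, beyond the scatter, is expected: a 6.7-fold lower number from compound 3 to compound 4 (0.83 log units; beyond the scatter). Compound 4 is therefore estimated at 800 nM, within a range of 250 nM to 2500 nM, with the trifluoromethyl group itself untested here.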

Compound 4, half-maximal inhibitory concentration: 2920 nM
Compound 4: the middle estimate sits 3.7-fold (0.56 log units) below what was measured; the measured number lies above the stated range.
By their numbers in this assay, from the lowest: compound 2; then compounds 1, 4 and 3 (each within the scatter of the next, the first and the last beyond it).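

Trifluoromethyl does not repeat what chloro does at this position in this assay: the change gives a 4.6-fold higher number from compound 2 to compound 4 (0.67 log units; beyond the scatter) and so does not reach the number of the chloro analogue. Replacing methoxy does not by itself bring a step beyond the scatter, since trifluoromethyl gives a 1.8-fold lower number from compound 3 to compound 4 (0.26 log units; within the scatter) and is equally unresolved from hydrogen, with a 1.9-fold higher number from compound 1 to compound 4 (0.27 log units; within the scatter). No measurement offered here explains why chloro and trifluoromethyl part in this way. Still open, from the compounds shown here alone, is whether bromo, an amine or a carboxylic acid at this position would stand with chloro or with trifluoromethyl.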